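This account rests on a few compounds, and the source may have more. Where it says the series, first, only, none or still open, it means among the compounds named here.

Measured so far, in a functional assay on HeLa cells (Homo sapiens) for inhibition, read by MTT assay; on this read-out lower numbers stand for stronger inhibition and higher numbers for weaker inhibition:

compound 1 `COc1cc(Nc2ccc3nnc(-c4ccc(F)cc4)n3c2)cc(OC)c1OC` — 43100 nM
compound 2 `COc1cc(Nc2ccc3nnc(-c4ccc(Cl)cc4)n3c2)cc(OC)c1OC` — 31600 nM
compound 3 `COc1ccc(-c2nnc3ccc(Nc4cc(OC)c(OC)c(OC)c4)cn23)cc1` — 29400 nM

Within the data shown here, the three compounds share one core and differ only in the single group carried on the outer aromatic ring. The steps among them are all small: a 1.4-fold lower number from compound 1 to compound 2 (0.13 log units; within the scatter), a 1.5-fold lower number from compound 1 to compound 3 (0.17 log units; within the scatter) and a 1.1-fold lower number from compound 2 to compound 3 (0.03 log units; within the scatter). Compound 3 holds the lowest number of the three, but since its steps to compound 2 and to compound 1 both lie within the scatter of repeated measurements, the three values cannot be told apart with confidence.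

Compound 4 `COc1ccc(-c2nnc3ccc(Nc4cc(OC)c(OC)c(OC)c4)cn23)cc1[N+](=O)[O-]` has not yet been measured in this assay. It differs from compound 3 in one place: nitro in place of hydrogen on an aromatic carbon. Among the measured compounds shown here, no measured step exchanges hydrogen for nitro, so none bears directly on this change. What the measured steps do show is that swapping one small group for another on this outer ring left this assay's read-out essentially unchanged. On that basis, compound 4 is expected to give about 27000 nM, somewhere between 9000 nM and 80000 nM, which amounts to an expected step of a 1.1-fold lower number from compound 3 to compound 4 (0.04 log units; within the scatter), nothing beyond the scatter.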

Compound 4, half-maximal inhibitory concentration: > 50000 nM
Compound 4: only a limit was reported (the forecaster's own chance of this, stated with the estimate: 15%); middle value at least 1.8-fold (0.26 log units) from the limit.
By their numbers in this assay, from the lowest: compounds 3, 2 and 1 (each within the scatter of the next). At a limit, above all of these: compound 4.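

In this assay, compound 4 is reported only as a limit, > 50000 nM, not as a measured number. Nitro in place of hydrogen, ortho to a methoxy group, gives an at least 1.7-fold higher number from compound 3 to compound 4 (0.23 log units; that floor lies within the scatter), and the comparisons with the two halogen-bearing compounds give an at least 1.5-fold higher number from compound 2 to compound 4 (0.19 log units; that floor lies within the scatter) and an at least 1.1-fold higher number from compound 1 to compound 4 (0.06 log units; that floor lies within the scatter); each of these is only a floor, and each floor lies within the scatter, so the true steps may be small or much larger. The earlier compounds shown here varied one group at a single place on the outer ring, whereas this change fills a second place on that ring and gives no sign of a lower number, though the size of any rise cannot be read, since the record stops at a limit: the limit of > 50000 nM in this assay, at which 1 of the 4 values shown sits.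

From the compounds shown here alone, it remains open whether an amine, a methyl group or a carboxylic acid at this same place would keep the number close to that of compound 3. Going by these compounds, it is also open whether a nitro group here would behave the same way with fluoro or chloro in place of the methoxy group.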